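This account rests on a few compounds, and the source may have more. Where it says the series, first, only, none or still open, it means among the compounds named here.

Compound 1 `CC(=O)c1ccc2[nH]c(-c3ccccc3)nc2c1` and compound 2 `CC(=O)c1ccc2[nH]c(-c3ccc(Cl)cc3)nc2c1` share one core, while compound 3 `C/C(=N\NC(N)=S)c1ccc2c(c1)nc(-c1ccccc1)n2C1CCCCC1` and compound 4 `C/C(=N\NC(N)=S)c1ccc2c(c1)nc(-c1ccc(Cl)cc1)n2C1CCCCC1` share another; the difference between the two cores is not broken down here. In an ADME assay on MDBK cells (Bos taurus) for cytotoxicity, read by MTT assay, with a stated time of 96 h (a higher number here means that more compound is tolerated, a lower number that less compound is tolerated), compound 1 gives > 100000 nM, which is a limit of the assay and not a number. Compound 2 likewise gives only a limit, > 100000 nM. The change from compound 1 to compound 2 is chloro in place of hydrogen on an aromatic carbon and its step, a step that the two limits leave unreadable from compound 1 to compound 2, cannot be read because the limit of > 100000 nM in this assay, at which 2 of the 3 values shown sit, holds both of them. For the measured compounds named here, compound 3 gives 24000 nM in this assay, the only number among the three values shown. The change from compound 3 to compound 4 is chloro in place of hydrogen on an aromatic carbon, the same change as that from compound 1 to compound 2, and it occurs in these two pairs only. Since the measured instance of this change is unreadable, the expectation for compound 4 rests on compound 3 alone, with 24000 nM as the anchor and no evidence for a shift in either direction. The expected step, a 1.2-fold lower number from compound 3 to compound 4 (0.08 log units; within the scatter), is small. Compound 4 is therefore estimated at 20000 nM, with a range from 8000 nM to 60000 nM.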

Compound 4, half-maximal cytotoxic concentration: > 100000 nM
Compound 4 was reported as a limit; the forecaster's own chance of this, stated with the estimate: 10%; middle value at least 5.0-fold (0.69 log units) from the limit.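

In this assay, chloro in place of hydrogen on an aromatic carbon gives an at least 4.1-fold higher number from compound 3 to compound 4 (0.61 log units; beyond the scatter), so on the core of compound 3 the change from phenyl to 4-chlorophenyl goes with more compound being tolerated. Going by these compounds, compound 4 stands at a limit of the assay and not at a number, and the true size of its step stays unknown. For the compounds shown here, whether the change acts alike on both cores cannot be said, because the step from compound 1 to compound 2 cannot be read and only one core gives a lower bound for the step, with the values held at one ceiling: the limit of > 100000 nM in this assay, at which 3 of the 4 values shown sit.

The compounds shown leave open how the difference between the two cores acts on its own, since no pair isolates it. They also leave open how a methoxy group or an amine in the place of the chloro would read on the core of compound 3, where the parent phenyl compound still gives a number.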